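Swapping phenyl for cyclopentyl on a sulfonyl group

The compounds below may be only part of what the source reports. "The series", "measured", "known", "first", "only" and "open" are said of these compounds alone.

compound 1 `O=C(Nc1cccn(Cc2ccccc2)c1=O)c1ccc2c(c1)B(O)OC2`: 3 ug/mL
compound 2 `O=C(Cc1ccc2c(c1)B(O)OC2)NS(=O)(=O)c1ccccc1`: 900 ug/mL
compound 3 `O=C(O)CCc1ccc2c(c1)B(O)OC2`: > 1000 ug/mL (a limit, not a number)

These three compounds share one core and have been measured in an ADME assay for solubility, in simulated intestinal fluid; on this read-out higher numbers stand for higher solubility and lower numbers for lower solubility. Compound 3 gives > 1000 ug/mL, which is a limit of the assay and not a number. Of the two actual numbers, compound 2 has the higher at 900 ug/mL and the nearest, compound 1 at 3 ug/mL, lies lower by well beyond the usual scatter.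

Compound 4 `O=C(Cc1ccc2c(c1)B(O)OC2)NS(=O)(=O)C1CCCC1` has not yet been measured. It keeps everything in compound 2 except one group, with cyclopentyl in place of phenyl on a sulfonyl sulfur. A six-membered aromatic ring of carbon only gives way to a five-membered non-aromatic ring of carbon only, and neither group carries a net charge.

Within the data shown here, no measured pair here tests a swap of this kind, so the expectation leans on compound 2, at 900 ug/mL, as the only close neighbour. The expected outcome in this assay is no change beyond the scatter, with an estimated 1.1-fold lower number from compound 2 to compound 4 (0.02 log units; within the scatter) in either direction. Compound 4 may also return only a limit rather than a number. For compound 4 the estimate is 850 ug/mL with an expected range from 350 ug/mL to 1000 ug/mL.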

Compound 4, solubility: 880 ug/mL
Compound 4: middle estimate off by 1.0-fold (0.02 log units), on the low side; measured number inside the range.
By their numbers in this assay, from the lowest: compound 1; then compounds 4 and 2 (each within the scatter of the next). At a limit, above all of these: compound 3.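

In this assay, putting cyclopentyl in place of phenyl on a sulfonyl sulfur gives a 1.0-fold lower number from compound 2 to compound 4 (0.01 log units; within the scatter). Among these compounds, until this pair, no two compounds differed in only one place, so nothing could be said about this position on its own; now a five-membered non-aromatic ring of carbon only is seen to read the same, within the scatter, as a six-membered aromatic ring of carbon only. Compound 3 is the one compound at a limit, and any rise from this position would have only a short stretch of the scale in which to appear as a number, because the read-out stops there: the limit of > 1000 ug/mL in this assay, at which 1 of the 4 values shown sits.

This single swap joins two rings of carbon only, both without a net charge, so it says little about how far the position can be changed before the read-out moves. As far as these compounds go, how an amine or a carboxylic acid on the ring at this sulfonyl sulfur, or a longer chain in place of the ring, would behave in this assay remains open.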